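Benzyloxy for nitro on the thiophene series

The compounds below may be only part of what the source reports. "The series", "measured", "known", "first", "only" and "open" are said of these compounds alone.

Compound 1 `COc1ccc(-c2sccc2-c2cc(OC)c(OC)c(OC)c2)cc1[N+](=O)[O-]` in a functional assay on SGC-7901 cells (Homo sapiens) for antiproliferative activity, read by MTT assay, with a stated time of 72 h (a lower number here means a stronger inhibitor, a higher number a weaker inhibitor), gives 3310 nM. Compound 2 `COc1ccc(-c2sccc2-c2cc(OC)c(OC)c(OC)c2)cc1OCc1ccccc1` carries the change (benzyloxy in place of nitro on an aromatic carbon). For compound 2 this assay reports only a limit, > 100000 nM. The step of an at least 30-fold higher number from compound 1 to compound 2 (1.48 log units; beyond the scatter) is therefore bounded by the limit of > 100000 nM in this assay, at which 1 of the 3 values shown sits. Compound 3 `CCOC(=O)c1cc(-c2ccc(OC)c([N+](=O)[O-])c2)c(-c2cc(OC)c(OC)c(OC)c2)s1` gives 19400 nM in this assay; the difference between the core of compound 3 and the core of compound 1 is not broken down here. Compound 4 `CCOC(=O)c1cc(-c2ccc(OC)c(OCc3ccccc3)c2)c(-c2cc(OC)c(OC)c(OC)c2)s1` is not yet measured and differs from compound 3 by benzyloxy in place of nitro on an aromatic carbon, the same change as before. For compound 4 a step of about a 7.7-fold higher number from compound 3 to compound 4 (0.89 log units; beyond the scatter) is expected, resting on the step of an at least 30-fold higher number from compound 1 to compound 2 (1.48 log units; beyond the scatter) seen with the same change. Compound 4 is thus estimated at 150000 nM, most likely reported only as the limit (the limit of > 100000 nM in this assay, at which 1 of the 3 values shown sits), with a range of 40000 nM to 600000 nM.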

Compound 4, half-maximal inhibitory concentration: > 100000 nM
Compound 4: a limit, no number; the forecaster's own chance of this, stated with the estimate: 75%; the middle value lies beyond the limit too.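

In this assay, benzyloxy in place of nitro gives a weaker compound on the second core as well, with an at least 5.1-fold higher number from compound 3 to compound 4 (0.71 log units; beyond the scatter). Compound 4 is reported only as a limit, > 100000 nM. The direction of the change therefore carries from one core to the other, but its size on either core cannot be fixed: the same change on two cores in this assay, an at least 30-fold higher number (1.48 log units; beyond the scatter) from compound 1 to compound 2 and an at least 5.1-fold higher number (0.71 log units; beyond the scatter) from compound 3 to compound 4; the limit leaves it open whether they differ.

The compounds shown leave open whether a smaller group in this place, such as an amine or a hydroxyl, would keep a measurable value on either core. They also leave open how a carboxylic acid or an amide in place of the ethyl ester on the core of compound 3 would read.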